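A few compounds are considered here, and "the series" means these few. Any claim that something is new, unique, unknown or untested is made for them only; others in the source may bear on it.

Measured so far, all in a functional assay on MDA-MB-231 cells (Homo sapiens) for antiproliferative activity, read by sulforhodamine B assay, with a stated time of 72 h; on this read-out lower numbers stand for stronger inhibition and higher numbers for weaker inhibition
- compound 1 `CCOC(=O)c1cnc2ccc(-c3cnc(OC)c(NS(C)(=O)=O)c3)cn12` gives 190 nM
- compound 2 `CCOC(=O)c1cc2cc(-c3cnc(OC)c(NS(=O)(=O)c4ccc(F)cc4)c3)ccc2[nH]1` gives 150 nM
- compound 3 `COc1ncc(-c2ccc3ncc(C(=O)N4CCC(OC(=O)c5ccccc5)CC4)n3c2)cc1NS(=O)(=O)c1ccc(F)cc1F` gives 1450 nM

Compound 1 lies within the scatter of compound 2, so these two cannot be ordered. Both numbers lie well under that of compound 3, and the gap from compound 1 to compound 3 is beyond the scatter.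

Next in the series is compound 4 `CCCCS(=O)(=O)Nc1cc(-c2ccc3ncc(C(=O)OCC)n3c2)cnc1OC`, which differs from compound 1 at one place: propyl in place of hydrogen on a saturated chain carbon bound to a sulfonyl sulfur. This is propyl in place of hydrogen on a saturated chain carbon bound to a sulfonyl sulfur, so methanesulfonamido becomes (butylsulfonyl)amino. For the measured compounds named here, no pair of measured compounds differs in only one place, so the data hold no direct precedent for this change, and the expectation is correspondingly loose.

It starts from compound 1 (190 nM). In this assay a modest move towards a higher number is expected, most likely no larger than the scatter, and a large loss is not assumed. The estimated step is a 1.5-fold higher number from compound 1 to compound 4 (0.17 log units; within the scatter) and remains tentative. For compound 4 the expected value is 280 nM, with an estimated range from 100 nM to 800 nM.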

Compound 4, half-maximal inhibitory concentration: 2320 nM
Compound 4: the middle estimate sits 8.3-fold (0.92 log units) below what was measured; the whole stated range lies below it.
By their numbers in this assay, from the lowest: compounds 2 and 1 (each within the scatter of the next); then compounds 3 and 4 (each within the scatter of the next).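

In this assay, for the compounds shown here, methanesulfonamido to (butylsulfonyl)amino is the first change that can be read on its own, and it gives a 12-fold higher number from compound 1 to compound 4 (1.09 log units; beyond the scatter) with the core and the ethyl ester unchanged. The place on a saturated chain carbon bound to a sulfonyl sulfur therefore does not accept this extension freely: propyl in place of hydrogen there is enough on its own to produce a large move towards weaker inhibition, beyond the scatter. No measurement on hand bears on what lies behind this loss, so the step stands as an observation on one pair.

Only methyl and butyl are shown on this sulfonyl group with this core, so it remains open whether the loss builds gradually with chain length or appears abruptly at some intermediate length, which ethylsulfonyl or propylsulfonyl analogues of compound 1 would settle. Also open, as far as these compounds go, is whether the loss follows the length of the chain or extends to any group larger than methyl, a question that a cyclopropyl or a trifluoromethyl group on the sulfonyl sulfur would address.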